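The source may hold more compounds than are shown below. What is called first, only, known or untested is meant among the compounds shown, and "the series" means these compounds.

Within this small set compound 2 `c1ccc(-c2cc(-c3ccccn3)nc(-c3ccccn3)c2)cc1` gives the lowest number: in a functional assay on HT-29 cells (Homo sapiens) for antiproliferative activity (a higher number here means a weaker inhibitor of growth, a lower number a stronger inhibitor of growth), compound 2 gives 0.0014 ug/mL. Compound 1 `c1ccc(-c2cc(-c3cccnc3)nc(-c3ccccn3)c2)cc1` carries pyridin-3-yl where compound 2 carries pyridin-2-yl. In this assay compound 1 gives 0.33 ug/mL, and there is a 240-fold lower number from compound 1 to compound 2 (2.37 log units; beyond the scatter). Compound 3 `c1ccc(-c2cc(-c3ccsc3)cc(-c3cccnc3)n2)nc1` gives 0.36 ug/mL in this assay. Compound 4 `c1ccc(-c2cc(-c3ccoc3)cc(-c3ccccn3)n2)nc1` is reached from compound 2 by a single change, (furan-3-yl in place of phenyl on an aromatic carbon), at a place on an aromatic carbon of a six-membered aromatic ring with 1 nitrogen, meta to two pyridin-2-yl groups and opposite the ring nitrogen. Among the measured compounds shown here, no measured step exchanges phenyl for furan-3-yl; the closest is the step with thiophen-3-yl in place of phenyl on an aromatic carbon, where a 1.1-fold higher number from compound 1 to compound 3 (0.04 log units; within the scatter). That exchange left the number unchanged once, so nothing beyond the scatter is expected here. The estimate therefore means a 1.4-fold higher number from compound 2 to compound 4 (0.15 log units; within the scatter), within the scatter. Compound 4 is thus expected to give 0.002 ug/mL in this assay, between 0.0007 ug/mL and 0.006 ug/mL.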

Compound 4, concentration for 50% growth inhibition: 0.0026 ug/mL
The estimate for compound 4 lay 1.3-fold (0.11 log units) below the measured number; the measured number falls inside the stated range.
By their numbers in this assay, from the lowest: compounds 2 and 4 (each within the scatter of the next); then compounds 1 and 3 (each within the scatter of the next).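

In this assay, the place opposite the ring nitrogen, meta to two pyridin-2-yl groups, takes furan-3-yl in place of phenyl with only a 1.9-fold higher number from compound 2 to compound 4 (0.27 log units; within the scatter) and no loss of the low number. Among the compounds shown here, the earlier exchange at this place, a 1.1-fold higher number from compound 1 to compound 3 (0.04 log units; within the scatter), was seen only with a pyridin-3-yl group in the core, so this result extends the finding to the core carrying two pyridin-2-yl groups. A six-membered aromatic ring of carbon only can thus give way here to a five-membered aromatic ring with 1 hetero atom in both cores.

Going by these compounds, whether an amine, a carboxylic acid or a longer chain at this place would leave the number equally unchanged remains open. So does whether a group other than these aromatic rings is accepted here at all. No measurement at hand explains why this exchange leaves the number within the scatter.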